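Cytotoxicity notes on an acetamido ester pair

The source may report more compounds than this note shows. Statements on the series, on what has been measured and on what is new or still open speak of the compounds shown alone.

Two compounds have numbers in an ADME assay on Vero cells (Chlorocebus sabaeus) for cytotoxicity, read by MTT assay, tested at 100 uM; on this read-out lower numbers stand for a stronger effect and higher numbers for a weaker effect at the one concentration tested. Compound 1 `CSc1ccc(C(=O)/C(=C/c2ccccn2)c2ccc(Cl)c(Cl)c2)cc1` gives 89.6% in this assay, and compound 2 `CCOC(=O)C(C(=O)c1ccc(OC)cc1)C(NC(C)=O)c1ccc(C(C)(C)C)cc1` gives 89.5% in this assay. The two numbers lie within the usual scatter of each other, so compound 2 cannot be separated from compound 1 on this read-out; both sit at the weak end of the effect. Among the compounds with values here, no pair differing in a single place has been measured, so no step is known. Compound 3 `CCOC(=O)C(C(=O)c1ccc(OC)cc1)C(NC(C)=O)c1ccc(OC)c(OC)c1` is not yet measured in this assay. It differs from compound 2 by 3,4-dimethoxyphenyl in place of 4-(tert-butyl)phenyl on a saturated chain carbon bound to an amide-type nitrogen and a saturated chain carbon. Nothing in the two measured compounds points to a change in cytotoxicity beyond the scatter from this exchange. For compound 3 the expected value in this assay is 88%, with a range from 72% to 99%. The expected step of a number 1.5 percentage points lower from compound 2 to compound 3 (within the scatter) is accordingly none beyond the scatter.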

Compound 3, a percentage reported as activity, at one concentration (the size of the read-out at that concentration, not a potency): 88.5%
Estimate against measurement, compound 3: 0.5 percentage points below, and the stated range covers the measured number.
By their numbers in this assay, from the lowest: compounds 3, 2 and 1 (each within the scatter of the next).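

In this assay, within the data shown here, the step of a number 1 percentage points lower from compound 2 to compound 3 (within the scatter) comes with 3,4-dimethoxyphenyl in place of 4-(tert-butyl)phenyl on a saturated chain carbon bound to an amide-type nitrogen and a saturated chain carbon, and it is the only single-place step so far. At this position, the read-out therefore does not separate an all-carbon group from one that brings in oxygen and hydrogen-bond acceptors, and compound 3 stays at the weak end of the effect with compound 2. Nothing on hand accounts for this result.

On these data alone, whether a primary amine on the aromatic ring at this position would leave the read-out equally flat remains open. So does the effect of a carboxylic acid in place of the ethyl ester.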